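From thiophen-3-yl to furan-2-yl at the limit

The source may hold more compounds than are shown below. What is called first, only, known or untested is meant among the compounds shown, and "the series" means these compounds.

Measured so far in a functional assay on HT-29 cells (Homo sapiens) for antiproliferative activity, read by MTT assay, with a stated time of 24 h; a higher number here means a weaker inhibitor, a lower number a stronger inhibitor (two of the three results are limits):
- compound 1 `COc1ccc(C(=O)/C=C/c2ccc([N+](=O)[O-])cc2)c2c1C=CC(C)(C)O2` gives a number (3730 nM)
- compound 2 `COc1ccc(C(=O)/C=C/c2ccccc2)c2c1C=CC(C)(C)O2` gives only a limit (> 10000 nM)
- compound 3 `COc1ccc(C(=O)/C=C/c2ccsc2)c2c1C=CC(C)(C)O2` gives only a limit (> 10000 nM)

Compound 3 therefore stands at a limit and has no number of its own in this assay. That reading is the common one in this small set (the limit of > 10000 nM in this assay, at which 2 of the 3 values shown sit). Compound 4 `COc1ccc(C(=O)/C=C/c2ccco2)c2c1C=CC(C)(C)O2` has furan-2-yl in place of thiophen-3-yl on a double-bonded chain carbon bound to a double-bonded chain carbon. Going by the values given here, no measured step makes this exact exchange. The closest one, from phenyl to thiophen-3-yl (a step that the two limits leave unreadable from compound 2 to compound 3), has no readable size. Compound 4 also carries no nitro group, and both steps that lose that group (an at least 2.6-fold higher number from compound 1 to compound 2 (0.42 log units; beyond the scatter) and an at least 2.6-fold higher number from compound 1 to compound 3 (0.42 log units; beyond the scatter)) go to higher numbers, so it is expected to stay near the limit. No step beyond the scatter is expected for compound 4 (a step that the limit leaves unreadable from compound 3 to compound 4). The estimated value for compound 4 is 12000 nM with an expected range from 5000 nM to 30000 nM and a report as a limit is the likeliest outcome.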

Compound 4, half-maximal inhibitory concentration: > 10000 nM
Compound 4 ended at the assay's limit (the forecaster's own chance of this, stated with the estimate: 75%); the middle value lies beyond the limit too.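

In this assay, compound 4 gives > 10000 nM, which is a limit of the assay and not a number. Furan-2-yl on this chain carbon therefore reads the same as thiophen-3-yl and phenyl, so exchanging the sulfur of one five-membered aromatic ring for the oxygen of another brings no measurable number here. Going by these compounds alone, the one step that can be read, an at least 2.6-fold higher number from compound 1 to compound 4 (0.42 log units; beyond the scatter), goes the same way as the two earlier steps away from 4-nitrophenyl. The steps among compound 2, compound 3 and compound 4 cannot be read, and compound 1 remains the only one of the four with a number: the limit of > 10000 nM in this assay, at which 3 of the 4 values shown sit.

From the compounds shown here alone, it remains open whether a 4-cyanophenyl or 4-aminophenyl group in place of 4-nitrophenyl would also give a number. Going by these compounds, how far compound 2, compound 3 and compound 4 differ beyond the limit also stays unknown.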